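Aryl Swaps on the Shared Core, All Beyond the Limit

This account rests on a few compounds, and the source may have more. Where it says the series, first, only, none or still open, it means among the compounds named here.

Compound 1 `Cc1ccccc1-n1nncc1CN1C(=O)C2(C(C#N)=C(N)Oc3c(N)cc4nc5ccccc5nc4c32)c2ccccc21`: in an ADME assay on L02 cells (Homo sapiens) for antiproliferative activity, read by MTT assay, with a stated time of 48 h (on this read-out lower numbers stand for stronger inhibition and higher numbers for weaker inhibition), compound 1 gives > 50000 nM, a limit of the assay.
Compound 2 `Cc1cccc(-n2nncc2CN2C(=O)C3(C(C#N)=C(N)Oc4c(N)cc5nc6ccccc6nc5c43)c3ccccc32)c1`: in this assay compound 2 gives > 50000 nM, again a limit.
Compound 3 `N#CC1=C(N)Oc2c(N)cc3nc4ccccc4nc3c2C12C(=O)N(Cc1cnnn1-c1ccc(Cl)cc1)c1ccccc12`: in this assay compound 3 gives > 50000 nM, also a limit.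

Compound 3 therefore stands where every measured member of this set stands, at the limit of > 50000 nM in this assay, at which 3 of the 3 values shown sit. Going by these compounds, none of the three steps among them can be read: a step that the two limits leave unreadable from compound 1 to compound 2, a step that the two limits leave unreadable from compound 1 to compound 3 and a step that the two limits leave unreadable from compound 2 to compound 3 are all hidden by the limits, so the size of the effect of changing the aryl group on the aromatic nitrogen is unknown from these data.

Compound 4 `N#CC1=C(N)Oc2c(N)cc3nc4ccccc4nc3c2C12C(=O)N(Cc1cnnn1-c1ccccc1Br)c1ccccc12` differs from compound 3 by 2-bromophenyl in place of 4-chlorophenyl on an aromatic nitrogen. All three measured steps bear on this change in kind, each swapping one aryl group for another at the same aromatic nitrogen, and each left no readable size. The expectation for compound 4 in this assay is a further limit rather than a number, with an estimated step that the limit leaves unreadable from compound 3 to compound 4. Compound 4 is accordingly estimated at 60000 nM, within a range from 20000 nM to 200000 nM.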

Compound 4, half-maximal inhibitory concentration: 29200 nM
Beside the measured number, compound 4's estimate is 2.1-fold (0.31 log units) above it; the measured number falls inside the stated range.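

Within the data shown here, with a 2-bromophenyl group on the aromatic nitrogen, compound 4 is the one member of the set that returns a number rather than a limit in this assay: the limit of > 50000 nM in this assay, at which 3 of the 4 values shown sit.
The aryl swap at this position therefore gives its first steps with a readable floor (an at least 1.7-fold lower number from compound 3 to compound 4 (0.23 log units; that floor lies within the scatter)), (an at least 1.7-fold lower number from compound 2 to compound 4 (0.23 log units; that floor lies within the scatter)) and (an at least 1.7-fold lower number from compound 1 to compound 4 (0.23 log units; that floor lies within the scatter)).
Each floor lies within the scatter, so these steps do not establish a real difference between compound 4 and the other three compounds, whose true values stay hidden behind their limits.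

Going by these compounds, the true size of these steps remains open, and so does whether the number follows the bromine or its place on the ring. A 2-chlorophenyl or a 4-bromophenyl group on the same nitrogen would separate those two changes.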